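This account rests on a few compounds, and the source may have more. Where it says the series, first, only, none or still open, it means among the compounds named here.

Measured compounds in an ADME assay on H9 cells (Homo sapiens) for cytotoxicity, read by XTT assay, with a stated time of 6 days; a lower number here means that less compound is tolerated, a higher number that more compound is tolerated:

- compound 1 `Cc1cc(C#N)cc(C)c1Oc1cc(Nc2ccc(C#N)cc2)c([N+](=O)[O-])cc1[N+](=O)[O-]`: > 58200 nM — this is a limit of the assay, not a number.
- compound 2 `Cc1cc(C)c(Oc2ccc(N)c(Nc3ccc(C#N)cc3)c2)c(C)c1`: 51000 nM
- compound 3 `Cc1cc(C#N)cc(C)c1Oc1ccc(N)c(Nc2ccc(C#N)cc2)c1`: 49800 nM

Within the data shown here, only two of the three values are plain numbers. Compound 2 and compound 3 sit within the scatter of each other: the step of a 1.0-fold lower number from compound 2 to compound 3 (0.01 log units; within the scatter) is too small to count as a real change. The value of compound 1 is a limit of > 58200 nM in this assay, at which 1 of the 3 values shown sits, and therefore does not say how far it lies from the other two.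

Compound 4 `Cc1cc(C)c(Oc2cc(Nc3ccc(C#N)cc3)c(N)cc2N)c(C)c1` is the next compound to be measured. It differs from compound 2 by amino in place of hydrogen on an aromatic carbon. Among the measured compounds shown here, the one measured step, from compound 2 to compound 3, concerns a different change (cyano in place of methyl) and was within the scatter, so no measured step speaks directly to adding an amino group. With nothing pointing in either direction, the expectation is that compound 4 behaves much like compound 2, and the expected step of a 1.0-fold lower number from compound 2 to compound 4 (0.01 log units; within the scatter) should stay within the scatter. Compound 4 is therefore estimated at 50000 nM, with a likely range from 20000 nM to 100000 nM; given that compound 1 already reached the limit, a limit rather than a number is also quite possible.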

Compound 4, half-maximal cytotoxic concentration: 50000 nM
Estimate against measurement, compound 4: no gap at the digits printed, within the range that was stated.
By their numbers in this assay, from the lowest: compounds 3, 4 and 2 (each within the scatter of the next). At a limit, above all of these: compound 1.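

In this assay, the aromatic carbon para to a (4-cyanophenyl)amino group takes an amino group in place of hydrogen without a change that can be told from scatter: a 1.0-fold lower number from compound 2 to compound 4 (0.01 log units; within the scatter). Among these compounds, this is the first look at this position and at adding a group there, since the earlier step, a 1.0-fold lower number from compound 2 to compound 3 (0.01 log units; within the scatter), was a swap of cyano for methyl, and it shows that a second amino group, meta to the first and ortho to a large group, is tolerated in this assay as far as these numbers can tell. Nothing measured here gives a reason for this outcome.

The same hydrogen could also give way to a hydroxyl group, a carboxylic acid or a longer chain such as butyl, and the compounds shown do not say whether any of these would shift the number. From the compounds shown here alone, compound 1 gives > 58200 nM, which is a limit of the assay and not a number, so its distance from the other compounds stays open.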